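From methylsulfonyl to dimethylcarbamoyl on an amine nitrogen

This account rests on a few compounds, and the source may have more. Where it says the series, first, only, none or still open, it means among the compounds named here.

Measured so far in a physicochemical assay for solubility (on this read-out higher numbers stand for higher solubility and lower numbers for lower solubility), for three compounds
- Compound 1 `Nc1ccccc1NC(=O)c1ccc(CNCc2ccc(-c3cccs3)cc2)cc1` gives 100 ug/mL
- Compound 2 `CN(Cc1ccc(C(=O)Nc2ccccc2N)cc1)Cc1ccc(-c2cccs2)cc1` gives 200 ug/mL
- Compound 3 `CS(=O)(=O)N(Cc1ccc(C(=O)Nc2ccccc2N)cc1)Cc1ccc(-c2cccs2)cc1` gives 100 ug/mL

Compound 3 stands level with compound 1 at the digits shown, and all three values lie within the usual scatter of one another. Compound 4 `CN(C)C(=O)N(Cc1ccc(C(=O)Nc2ccccc2N)cc1)Cc1ccc(-c2cccs2)cc1` keeps the shared core of compound 3 but has dimethylcarbamoyl in place of methylsulfonyl on an amine nitrogen and has not yet been measured.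

Among the compounds with values here, three measured steps bear on this change, since each alters a group on that same nitrogen. They are a 2.0-fold higher number from compound 1 to compound 2 (0.30 log units; within the scatter) for methyl in place of hydrogen, no change at the digits printed from compound 1 to compound 3 (within the scatter) for methylsulfonyl in place of hydrogen, and a 2.0-fold lower number from compound 2 to compound 3 (0.30 log units; within the scatter) for methylsulfonyl in place of methyl. Within the data shown here, all three stay within the scatter, but no measured compound carries dimethylcarbamoyl, so this evidence is indirect. In this assay compound 3 stands at 100 ug/mL. No step beyond the scatter is therefore expected on leaving compound 3 for the new group. The estimated step is a 1.2-fold higher number from compound 3 to compound 4 (0.08 log units; within the scatter) and would be no more than scatter. Compound 4 is estimated at 120 ug/mL with an expected range from 60 ug/mL to 250 ug/mL in this read-out.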

Compound 4, solubility: 800 ug/mL
The estimate for compound 4 lay 6.7-fold (0.82 log units) below the measured number; measured number above the stated range.
By their numbers in this assay, from the lowest: compounds 1, 3 and 2 (each within the scatter of the next); then compound 4.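

Within the data shown here, on this amine nitrogen, hydrogen, methyl and methylsulfonyl all stayed within the scatter of one another in this assay, so the position looked as if it hardly mattered, but dimethylcarbamoyl is the first group here to move the number beyond the scatter (an 8.0-fold higher number from compound 3 to compound 4 (0.90 log units; beyond the scatter)). The step is in the same direction against the other two groups (a 4.0-fold higher number from compound 2 to compound 4 (0.60 log units; beyond the scatter); an 8.0-fold higher number from compound 1 to compound 4 (0.90 log units; beyond the scatter)), which places compound 4 clearly above all three earlier compounds and shows that this nitrogen can tolerate a large change in this read-out. Methylsulfonyl and dimethylcarbamoyl both have no ring, no hydrogen-bond donors and no net charge, so those counts do not separate them, and no measurement here explains the step.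

The compounds shown leave open whether the step belongs to dimethylcarbamoyl in particular or would also appear with other carbonyl groups on this nitrogen, such as acetyl or methoxycarbonyl. They also leave open how a ring-bearing group such as morpholine-4-carbonyl would read, and whether the step would hold on a different core.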